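A few compounds are considered here, and "the series" means these few. Any claim that something is new, unique, unknown or untested is made for them only; others in the source may bear on it.

Measured compounds:
compound 1 `CC(C)(C)[C@]1(c2ccccc2)OCC[C@H](CCNCc2ccccc2)O1`: 253 nM
compound 2 `c1ccc(CNCC[C@@H]2CCO[C@H](c3ccccc3)O2)cc1`: 6 nM
compound 3 `NCC[C@H]1CCO[C@@H](c2ccccc2)O1`: > 10000 nM

In an assay on brain for displacement of a labelled ligand from Sigma non-opioid intracellular receptor 1 (Cavia porcellus) (a lower number here means a stronger inhibitor, a higher number a weaker inhibitor), compound 1 gives 253 nM and compound 2 gives 6 nM. For compound 3 only a limit is reported in this assay, > 10000 nM, which is the limit of > 10000 nM in this assay, at which 1 of the 3 values shown sits; compound 3 thus stands at the bottom of the numbers shown, with no measured value of its own.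

Compound 4 `c1ccc(CNCC[C@H]2CCO[C@@H](c3ccccc3)O2)cc1` is not yet measured. It differs from compound 3 by benzyl in place of hydrogen on an amine nitrogen. Compound 3 itself stands only at a limit. Since compound 2, which carries the same group on its amine nitrogen, gives 6 nM, a large step toward stronger binding is expected, the step from compound 3 to compound 4 estimated at an at least 330-fold lower number from compound 3 to compound 4 (2.52 log units; beyond the scatter). The value of compound 4 is estimated at 30 nM, expected between 5 nM and 400 nM.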

Compound 4, inhibition constant: 50 nM
Compound 4: middle estimate off by 1.7-fold (0.22 log units), on the low side; measured number inside the range.
By their numbers in this assay, from the lowest: compound 2; then compound 4; then compound 1. At a limit, above all of these: compound 3.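

Compound 3 stands only at a limit in this assay (> 10000 nM). Benzyl in place of hydrogen on an amine nitrogen still gives a large gain in the mirror-image configuration (an at least 200-fold lower number from compound 3 to compound 4 (2.30 log units; beyond the scatter)), so the gain is not confined to the configuration of compound 2. Configuration alone moves the number (an 8.3-fold higher number from compound 2 to compound 4 (0.92 log units; beyond the scatter)), and hydrogen in place of tert-butyl on a saturated ring carbon also moves it (a 5.1-fold lower number from compound 1 to compound 4 (0.70 log units; beyond the scatter)). Open, on these data alone, is how a methyl or phenylethyl group on the amine nitrogen compares with benzyl. Also open, as far as these compounds go, is how a methyl group on that ring carbon compares with tert-butyl.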